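Swapping a phenoxy arm for a benzyl arm on a shared core

The source may report more compounds than this note shows. Statements on the series, on what has been measured and on what is new or still open speak of the compounds shown alone.

Three measured compounds share one core. Compound 1 `COc1ccc(Oc2ccc3cc(NC(=O)c4ccc(OC(C)=O)c(CC=C(C)C)c4)c(=O)oc3c2C)cc1` gives 18200 nM in a functional assay on MCF7 cells (Homo sapiens) for antiproliferative activity; a lower number here means a stronger inhibitor, a higher number a weaker inhibitor. Compound 2 `COc1ccc(Oc2ccc3cc(NC(=O)c4ccc(O)c(CC=C(C)C)c4)c(=O)oc3c2C)cc1` gives 6510 nM, the lowest of the three numbers; the change from compound 1, hydrogen in place of acetyl, gave a 2.8-fold lower number from compound 1 to compound 2 (0.45 log units; beyond the scatter). Compound 3 `CC(=O)Oc1ccc(C(=O)Nc2cc3ccc(Oc4ccc(C(C)(C)C)cc4)c(C)c3oc2=O)cc1CC=C(C)C` gives 75000 nM, and the change from compound 1, tert-butyl in place of methoxy, gave a 4.1-fold higher number from compound 1 to compound 3 (0.61 log units; beyond the scatter). Compound 4 `COc1ccc(Cc2ccc3cc(NC(=O)c4ccc(O)c(CC=C(C)C)c4)c(=O)oc3c2C)cc1` differs from compound 2 by 4-methoxybenzyl in place of 4-methoxyphenoxy on an aromatic carbon. Neither measured step touches this link, so neither guides the direction directly; both were modest, which suggests a modest step here as well, with its direction open. Compound 4 is therefore expected to give about 8000 nM, within 3000 nM to 25000 nM. This estimate means a 1.2-fold higher number from compound 2 to compound 4 (0.09 log units; within the scatter).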

Compound 4, half-maximal inhibitory concentration: 13300 nM
For compound 4 the middle estimate is 1.7-fold (0.22 log units) below the measured one; the range from low to high includes it.
By their numbers in this assay, from the lowest: compound 2; then compounds 4 and 1 (each within the scatter of the next); then compound 3.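

In this assay, 4-methoxybenzyl in place of 4-methoxyphenoxy gave a 2.0-fold higher number from compound 2 to compound 4 (0.31 log units; beyond the scatter). This shows that the arm's connection to the shared core matters, even though the arm keeps the same number of heavy atoms and its aromatic ring. Nothing available explains this shift. The compounds shown leave open how an amine connection or a longer chain in the same place would compare. They also leave open whether this swap would give a similar step with an acetyl group on the oxygen.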